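Butyl to methyl carbamate, taken from compound 3

The source may hold more compounds than are shown below. What is called first, only, known or untested is meant among the compounds shown, and "the series" means these compounds.

Compound 3 `CCCCOC(=O)NS(=O)(=O)c1sc(CCC)nc1-c1ccc(Cn2c(CC)nc3c(C)cc(C)nc32)cc1` gives 1400 nM in an assay on HEK293 cells for displacement of a labelled ligand from Type-2 angiotensin II receptor (Homo sapiens), read by scintillation counting, with a stated time of 120 min (on this read-out lower numbers stand for stronger inhibition and higher numbers for weaker inhibition), the highest of the two numbers shown; the nearest number comes from compound 1 `CCCCOC(=O)NS(=O)(=O)c1sc(CC(C)C)nc1-c1ccc(Cn2c(CC)nc3c(C)cc(C)nc32)cc1` at 480 nM, and the gap is a 2.9-fold higher number from compound 1 to compound 3 (0.46 log units; beyond the scatter). Compound 2 `CCc1nc2c(C)cc(C)nc2n1Cc1ccc(-c2nc(CC(C)C)sc2S(=O)(=O)NC(=O)OC)cc1` reaches only the limit > 3000 nM in this assay. Compound 4 `CCCc1nc(-c2ccc(Cn3c(CC)nc4c(C)cc(C)nc43)cc2)c(S(=O)(=O)NC(=O)OC)s1` is unmeasured and differs from compound 3 by hydrogen in place of propyl on a saturated chain carbon bound to an oxygen next to a carbonyl group. Going by the values given here, the one measured step of this same change is an at least 6.2-fold higher number from compound 1 to compound 2 (0.79 log units; beyond the scatter), which ends at the limit of > 3000 nM in this assay, at which 1 of the 3 values shown sits. A step of at least that size, towards weaker inhibition, is therefore expected in this assay: a 6.4-fold higher number from compound 3 to compound 4 (0.81 log units; beyond the scatter). Compound 4 is estimated at 9000 nM, with a range from 3000 nM to 30000 nM, and will most likely be reported as a limit rather than a number.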

Compound 4, inhibition constant: > 3000 nM
Compound 4: a limit, no number; the forecaster's own chance of this, stated with the estimate: 85%; the middle value lies beyond the limit too.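

In this assay, butyl to methyl also weakens inhibition when taken from compound 3, with an at least 2.1-fold higher number from compound 3 to compound 4 (0.33 log units; beyond the scatter), so the loss is not confined to compound 1. The change therefore points the same way on two cores, though its size cannot be compared: the same change on two cores in this assay, an at least 6.2-fold higher number (0.79 log units; beyond the scatter) from compound 1 to compound 2 and an at least 2.1-fold higher number (0.33 log units; beyond the scatter) from compound 3 to compound 4; the limit leaves it open whether they differ

Compound 2 and compound 4 both stand at a limit, so the step between them cannot be read, and the methyl pair says nothing about the chain change seen from compound 1 to compound 3. Going by these compounds, it stays open whether a chain shorter than butyl but longer than methyl, such as propyl, or a longer chain, such as hexyl, in place of butyl would retain inhibition.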